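A few compounds are considered here, and "the series" means these few. Any claim that something is new, unique, unknown or untested is made for them only; others in the source may bear on it.

Measured so far in a functional assay on a cell-free system (Platelet, plasma, Oryctolagus cuniculus) for inhibition, with a stated time of 5 min, at 37 degrees C; a lower number here means a stronger inhibitor, a higher number a weaker inhibitor:

Compound 1 `COc1cc(/C=C/C(=O)O)ccc1OC(=O)c1nc(C)c(C)nc1C` gives 44600 nM in this assay.
Compound 2 `COc1cc(/C=C/C(=O)O)cc(OC)c1OC(=O)c1nc(C)c(C)nc1C` gives 82300 nM in this assay.
Compound 3 `CCOC(=O)/C=C/c1cc(OC)ccc1OC(=O)c1nc(C)c(C)nc1C` gives 196000 nM in this assay.

Compound 4 `CCOC(=O)/C=C/c1ccccc1OC(=O)c1nc(C)c(C)nc1C` has not yet been measured. It is made from compound 3 by one change, (hydrogen in place of methoxy on an aromatic carbon). The same kind of change has already been made once among the measured compounds, from compound 2 to compound 1: hydrogen in place of methoxy on an aromatic carbon. That earlier step gave a 1.8-fold lower number from compound 2 to compound 1 (0.27 log units; within the scatter), so removing the methoxy group there left the inhibition much where it was.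

The surroundings of the change are not identical, though. In the earlier pair the carbon that loses its methoxy is ortho to a large group, meta to a 2-carboxyethenyl group and meta to a methoxy group; in the new pair it is meta to a 2-(ethoxycarbonyl)ethenyl group and para to a large group. The cores of compound 2 and compound 3 also differ, and that difference is not broken down here. Compound 3 stands with the highest number of the three measured compounds, beyond the scatter from both of the others.

Among the compounds with values here, with only one earlier example, and that one within the scatter, the expectation for the step of a 1.2-fold lower number from compound 3 to compound 4 (0.06 log units; within the scatter) in this assay is for a small step, resting on compound 2 to compound 1 giving a 1.8-fold lower number from compound 2 to compound 1 (0.27 log units; within the scatter). Compound 4 is therefore expected to give about 170000 nM in this assay, most likely between 60000 nM and 500000 nM.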

Compound 4, half-maximal inhibitory concentration: 110000 nM
For compound 4 the middle estimate is 1.5-fold (0.19 log units) above the measured one, and the stated range covers the measured number.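

In this assay, putting hydrogen in place of the methoxy group gives a 1.8-fold lower number from compound 3 to compound 4 (0.25 log units; within the scatter), so this step on its own is too small to be read as a real change in inhibition. The same swap on a second core gave a step of much the same size, and the two agree: the same change on two cores in this assay, a 1.8-fold lower number (0.27 log units; within the scatter) from compound 2 to compound 1 and a 1.8-fold lower number (0.25 log units; within the scatter) from compound 3 to compound 4, 1.0-fold (0.02 log units) apart, within the scatter of two such steps

This suggests that, for these two pairs, the change carries from one core to the other as a small step, even though one pair has a free carboxylic acid and the other an ethyl ester, and the methoxy group leaves a different place on the ring in each. It does not show that the methoxy group matters or does not matter on other cores, and two pairs are too few to make a rule for the series.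

The compounds shown leave open whether a different group on this aromatic carbon, such as a chlorine atom, an amine or a longer ethoxy group, would move the number beyond the scatter. They also leave open how the same swap behaves when the ethyl ester gives way to an amide.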